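The source may hold more compounds than are shown below. What is called first, only, known or untested is meant among the compounds shown, and "the series" means these compounds.

Of the compounds shown here, two have been measured. Compound 1, `CCC1(Cc2ccccc2)OS(=O)(=O)C=C1OCc1ccc(Cl)c(Cl)c1`, gives 36700 nM in an ADME assay on HEL cells (Homo sapiens) for cytotoxicity, with a stated time of 3 days; on this read-out higher numbers stand for lower toxicity in this test and lower numbers for higher toxicity in this test. Compound 2, `O=S1(=O)C=C(OCc2ccccc2)C(Cc2ccccc2)(Cc2ccccc2)O1`, gives 200000 nM in this assay.

Of these two numbers, compound 1 holds the lower one, and the gap to compound 2 lies beyond the usual scatter, so compound 1 is the more toxic of the pair in this test.

Compound 3, `CCC1(Cc2ccccc2)OS(=O)(=O)C=C1OCc1ccc(OC)cc1`, has not yet been measured. It differs from compound 1 in a single place: 4-methoxyphenyl in place of 3,4-dichlorophenyl on a saturated chain carbon bound to an oxygen on an unsaturated carbon. Among the measured compounds shown here, no measured pair shows this change, so the data give no direct guide to its size. The step from compound 1 to compound 3 in this assay is expected to be modest and towards a higher number, at a 1.6-fold higher number from compound 1 to compound 3 (0.21 log units; within the scatter), though it could also fall within the scatter. Compound 3 is thus estimated at 60000 nM, with a range from 20000 nM to 200000 nM.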

Compound 3, half-maximal cytotoxic concentration: > 200000 nM
Compound 3 was reported as a limit; the forecaster's own chance of this, stated with the estimate: 25%; at least 3.3-fold (0.52 log units) between middle value and limit.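

Compound 3 sits at a limit of the assay, so its value is not an exact number: the limit of > 200000 nM in this assay, at which 1 of the 3 values shown sits.

Even so, 4-methoxyphenyl in place of 3,4-dichlorophenyl on a saturated chain carbon bound to an oxygen on an unsaturated carbon gives an at least 5.4-fold higher number from compound 1 to compound 3 (0.73 log units; beyond the scatter), and the true step may be larger. Among the compounds shown here, this is the first single-place comparison, and it shows that changing this aromatic group alone, with the rest of the molecule held the same, is enough to shift the result towards lower toxicity in this test.

As far as these compounds go, it remains open how much of the step comes from losing the two chlorines and how much from gaining the methoxy group. A plain phenyl, a 4-chlorophenyl or a 4-aminophenyl at this place on the core of compound 1 could help separate the two.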